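The source may hold more compounds than are shown below. What is called first, only, known or untested is meant among the compounds shown, and "the series" means these compounds.

Series notes. Among the compounds with values here, the two compounds measured so far share one core, seen in compound 1 `O=C(N1CCC=C[C@@H]1Cc1ccccc1)n1cc(-c2ccc(-c3ccccc3)cc2)nn1` and compound 2 `O=C(N1C[C@H](O)C=C[C@@H]1COCc1ccccc1)n1cc(-c2ccc(-c3ccccc3)cc2)nn1`. In an assay on HEK293 cells for inhibition of Monoacylglycerol lipase ABHD6 (Homo sapiens), read by fluorescence (a higher number here means a weaker inhibitor, a lower number a stronger inhibitor), compound 1 gives 2.51 nM. In this assay, within the data shown here, compound 2 gives 5.01 nM, the larger of the two numbers in hand, with compound 1 as its only neighbour; that gap lies within the scatter, so the two compounds are not separated by this read-out. Among the measured compounds shown here, no single-change step between measured compounds is available, since compound 1 and compound 2 differ in more than one place.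

Compound 3 `O=C(N1C[C@H](O)C=C[C@@H]1Cc1ccccc1)n1cc(-c2ccc(-c3ccccc3)cc2)nn1` is not yet measured. It derives from compound 2 by phenyl in place of benzyloxy on a saturated chain carbon bound to a saturated ring carbon. Compound 3 thus carries the benzyl group of compound 1 on the core of compound 2, placing it between the two measured compounds in structure. Both measured carriers of this core fall close together in this assay, compound 1 at 2.51 nM and compound 2 at 5.01 nM. The step of a 1.4-fold lower number from compound 2 to compound 3 (0.16 log units; within the scatter) is expected to stay within the scatter, with no change in either direction claimed. For compound 3 the estimated value in this assay is 3.5 nM, with a range from 1.5 nM to 8 nM.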

Compound 3, half-maximal inhibitory concentration: 3.16 nM
The estimate for compound 3 lay 1.1-fold (0.04 log units) above the measured number; the measured number falls inside the stated range.
By their numbers in this assay, from the lowest: compounds 1, 3 and 2 (each within the scatter of the next).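

In this assay the change from (benzyloxy)methyl to benzyl on the core of compound 2 gives a 1.6-fold lower number from compound 2 to compound 3 (0.20 log units; within the scatter) and so does not separate the two compounds, which shows that this saturated chain carbon can carry either group with no readable shift. Hydroxy in place of hydrogen on a saturated ring carbon can now be read as a single change, and it gives a 1.3-fold higher number from compound 1 to compound 3 (0.10 log units; within the scatter), so this read-out does not separate that pair either. The two differences between compound 1 and compound 2, previously seen only together, have now each been seen alone, and no measurement available here accounts for these results.

The compounds shown leave open whether an amine or a carboxylic acid in place of the hydroxy on that saturated ring carbon would move the number beyond the scatter. They also leave open whether a longer chain carrying the phenyl ring, beyond benzyl and (benzyloxy)methyl, would do so, as no change at either place has yet produced a step beyond the scatter.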